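Urea series: aryl group on the amide nitrogen of compound 4

The compounds below may be only part of what the source reports. "The series", "measured", "known", "first", "only" and "open" are said of these compounds alone.

compound 1 `O=C(NC1CCC(O)CC1)N1CCC(c2nc(-c3ccc4ccccc4n3)no2)CC1` — 2700 nM
compound 2 `Cn1c(-c2noc(C3CCN(C(=O)NC4CCCCC4)CC3)n2)nc2ccccc21` — 89 nM
compound 3 `C[C@H]1C[C@H](c2nc(-c3ccc4ccccc4n3)no2)CCN1C(=O)Nc1ccccc1Cl` — 900 nM

In a functional assay on Shh Light II cells (Mus musculus) for inhibition, read by a luciferase reporter (on this read-out higher numbers stand for weaker inhibition and lower numbers for stronger inhibition), compound 1 gives 2700 nM, the highest of the three numbers; compound 3 and compound 2 both lie beyond the scatter below it. Compound 4 `O=C(Nc1cccnc1Cl)N1CCC(c2nc(-c3ccc4ccccc4n3)no2)CC1` differs from compound 1 by 2-chloropyridin-3-yl in place of 4-hydroxycyclohexyl on an amide-type nitrogen. Within the data shown here, no measured pair of this series differs in that place alone, so the direction of the step can only be read from compound 3, which carries an aryl group bearing chlorine on the amide-type nitrogen and gives 900 nM. A modest step toward stronger inhibition is expected, a 3.0-fold lower number from compound 1 to compound 4 (0.48 log units; beyond the scatter), because compound 3 stands at 900 nM against compound 1. Compound 4 is estimated to give 900 nM, within 250 nM to 3000 nM.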

Compound 4, half-maximal inhibitory concentration: 1600 nM
The estimate for compound 4 lay 1.8-fold (0.25 log units) below the measured number; low and high end bracket the measured number.
By their numbers in this assay, from the lowest: compound 2; then compounds 3, 4 and 1 (each within the scatter of the next, the first and the last beyond it).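

Among these compounds, the first direct pair at this position shows that the exchange of 4-hydroxycyclohexyl for 2-chloropyridin-3-yl on the amide-type nitrogen gives a 1.7-fold lower number from compound 1 to compound 4 (0.23 log units; within the scatter). A six-membered non-aromatic ring of carbon only and a six-membered aromatic ring with a hetero atom are therefore not told apart here, on the core of compound 1. Nothing available accounts for this result.

Going by these compounds, whether the chlorine or the ring nitrogen contributes anything stays open. So does the standing of an unsubstituted pyridin-3-yl or a 4-aminocyclohexyl on the same nitrogen.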